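The compounds below may be only part of what the source reports. "The series", "measured", "known", "first", "only" and "open" are said of these compounds alone.

In a functional assay (aorta) with Rattus norvegicus as the target (a lower number here means that less compound is needed, a higher number that more compound is needed for the effect), compound 1 (`COc1ccc(-c2nc(CNC(C)=O)sc2-c2ccc(OC)cc2)cc1`) gives 8.1 uM and compound 2 (`COc1ccc(-c2nc(CNC(=O)N3CCOCC3)sc2-c2ccc(OC)cc2)cc1`) gives 12 uM. These two numbers lie within the usual scatter of each other, so compound 2 cannot be separated from compound 1 on this evidence. The next structure, compound 3 (`COc1ccc(-c2nc(C(=O)N3CCOCC3)sc2-c2ccc(OC)cc2)cc1`), keeps both 4-methoxyphenyl groups but carries (morpholin-4-yl)carbonyl in place of (((morpholin-4-yl)carbonyl)amino)methyl on an aromatic carbon. For the measured compounds named here, only one measured step bears on this change, and only indirectly. That step is a 1.5-fold higher number from compound 1 to compound 2 (0.17 log units; within the scatter), and it changes only the group carried on the carbonyl. Going by the values given here, both measured compounds keep the amino and methyl portion that is lost in compound 3, so the data contain no direct precedent for removing it. Among the compounds with values here, with so small a step as the only guide, no shift beyond the scatter is expected in this assay, although the uncertainty is wide. The expected step is a 1.2-fold lower number from compound 2 to compound 3 (0.08 log units; within the scatter). Compound 3 is estimated at 10 uM, with an expected range from 3 uM to 35 uM.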

Compound 3, concentration for half-maximal effect: < 100 uM
Compound 3: only a limit was reported (the forecaster's own chance of this, stated with the estimate: 10%); the middle value does not contradict the limit.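

In this assay compound 3 gives < 100 uM, which is a limit and not a number. The steps to compound 3 from compound 1 and from compound 2 therefore cannot be read: the limit of < 100 uM in this assay, at which 1 of the 3 values shown sits.

The compounds shown leave open whether (morpholin-4-yl)carbonyl on that aromatic carbon changes the amount of compound needed, and in which direction.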